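Pentafluoroethyl in place of a sulfur-fluorine group on the aryl ether

This account rests on a few compounds, and the source may have more. Where it says the series, first, only, none or still open, it means among the compounds named here.

Compound 1 `CC(O)(COc1ccc(S(F)(F)(F)(F)F)cc1)C(=O)Nc1cc(C(F)(F)F)cc(C(F)(F)F)c1` gives 3200 nM in a functional assay on CWR22R cells (Homo sapiens) for antiproliferative activity, read by propidium iodide staining, with a stated time of 96 h; a higher number here means a weaker inhibitor, a lower number a stronger inhibitor.
Compound 2 `CC(O)(COc1cccc(S(F)(F)(F)(F)F)c1)C(=O)Nc1cc(C(F)(F)F)cc(C(F)(F)F)c1` gives 2300 nM in this assay.
Compound 3 `CC(O)(COc1cccc(C(F)(F)C(F)(F)F)c1)C(=O)Nc1cc(C(F)(F)F)cc(C(F)(F)F)c1` gives 4100 nM in this assay.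

From compound 2 to compound 3 the change is a group of 7 heavy atoms (2 carbon, 5 fluorine; no ring) in place of a group of 6 heavy atoms (5 fluorine, 1 sulfur; no ring), on an aromatic carbon, and the measured step was a 1.8-fold higher number from compound 2 to compound 3 (0.25 log units; within the scatter). Compound 4 `CC(O)(COc1ccc(C(F)(F)C(F)(F)F)cc1)C(=O)Nc1cc(C(F)(F)F)cc(C(F)(F)F)c1` carries the same kind of change made on compound 1: a group of 7 heavy atoms (2 carbon, 5 fluorine; no ring) in place of a group of 6 heavy atoms (5 fluorine, 1 sulfur; no ring), on an aromatic carbon. The surroundings differ: in compound 3 the new group stands meta to a large group, in compound 4 para to a large group. The difference between the cores of compound 1 and compound 2 is not broken down here; their values in this assay lie within the scatter of each other. Within the data shown here, for compound 4 a step of a 1.6-fold higher number from compound 1 to compound 4 (0.19 log units; within the scatter) is expected, because a 1.8-fold higher number from compound 2 to compound 3 (0.25 log units; within the scatter) is the only comparable step seen. Compound 4 is therefore estimated at 5000 nM, between 2500 nM and 10000 nM.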

Compound 4, half-maximal inhibitory concentration: 2500 nM
Compound 4: the middle estimate sits 2.0-fold (0.30 log units) above what was measured; the measured number falls inside the stated range.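

In this assay, putting 1,1,2,2,2-pentafluoroethyl in place of the sulfur-fluorine group gives a 1.3-fold lower number from compound 1 to compound 4 (0.11 log units; within the scatter). Set beside the same change on the other core, this step does not differ from the first by more than repeat measurements would: the same change on two cores in this assay, a 1.8-fold higher number (0.25 log units; within the scatter) from compound 2 to compound 3 and a 1.3-fold lower number (0.11 log units; within the scatter) from compound 1 to compound 4, 2.3-fold (0.36 log units) apart, within the scatter of two such steps. On these two cores the change therefore leaves the number within the scatter, but two small steps do not show that it would do so on other cores, and they cannot rule out a small real difference hidden in the scatter.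

The compounds shown leave open whether a different group on this aromatic carbon, such as an amine, a carboxylic acid or a longer chain, would shift the number beyond the scatter.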